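Acetamido for Hydroxy on the Triazole-Bound Aryl Ring

This account rests on a few compounds, and the source may have more. Where it says the series, first, only, none or still open, it means among the compounds named here.

Measured compounds:
Compound 1, `C#CCO/N=C1/C[C@@H](c2ccc(OC)cc2)Oc2cc(OC)c(CC=C(C)C)cc21`: 61%
Compound 2, `COc1ccc([C@@H]2C/C(=N/OCc3cn(-c4ccc(O)cc4)nn3)c3cc(CC=C(C)C)c(OC)cc3O2)cc1`: 63%
Compound 3, `C#CCOc1ccc([C@@H]2CC(=O)c3cc(CC=C(C)C)c(OC)cc3O2)cc1`: 68%

Three compounds sharing one core were tested in a functional assay on MCF7 cells (Homo sapiens) for inhibition, read by sulforhodamine B assay, with a stated time of 48 h, tested at 50 uM; on this read-out higher numbers stand for more inhibition of growth at the one concentration tested and lower numbers for less inhibition of growth. Compound 2 stands second highest of the three numbers, yet every gap is within the scatter: compound 1 lies nearest, the step of a number 2 percentage points higher from compound 1 to compound 2 (within the scatter) being within the scatter, and compound 3, with 68%, lies furthest but also within the scatter.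

Compound 4, `COc1ccc([C@@H]2C/C(=N/OCc3cn(-c4ccc(NC(C)=O)cc4)nn3)c3cc(CC=C(C)C)c(OC)cc3O2)cc1`, is the next member. It differs from compound 2 as follows: acetamido in place of hydroxy on an aromatic carbon.

For the measured compounds named here, only one measured step is known here, that from compound 1 to compound 2, which replaced ethynyl by 1-(4-hydroxyphenyl)-1H-1,2,3-triazol-4-yl and changed the number by a number 2 percentage points higher from compound 1 to compound 2 (within the scatter), within the scatter. Going by the values given here, no measured pair touches the hydroxy group itself, so nothing in the data points to a change beyond the scatter when acetamido replaces hydroxy. Compound 4 is therefore expected to sit close to compound 2, with an estimated step of no change at the digits printed from compound 2 to compound 4 (within the scatter). The estimate for compound 4 in this assay is 63%, with a likely range from 50% to 76%.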

Compound 4, percent growth inhibition at one concentration: 0%
Estimate against measurement, compound 4: 63 percentage points above; the measured number lies below the stated range.
By their numbers in this assay, from the lowest: compound 4; then compounds 1, 2 and 3 (each within the scatter of the next).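

In this assay, the 4-hydroxyphenyl to 4-acetamidophenyl change gave a number 63 percentage points lower from compound 2 to compound 4 (beyond the scatter), so this position on the aromatic ring, para to a large group, is far from indifferent to what it carries. The earlier step, a number 2 percentage points higher from compound 1 to compound 2 (within the scatter), had shown only that the whole 1-(4-hydroxyphenyl)-1H-1,2,3-triazol-4-yl group could stand in place of ethynyl with no change beyond the scatter, whereas a single exchange at the far end of that group now takes compound 4 to 0%, even though acetamido has the same hydrogen-bond donor and acceptor counts as hydroxy, no net charge, and 4 heavy atoms against 1. Nothing available on these compounds explains why this exchange has so large an effect.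

As far as these compounds go, it remains open whether the result reflects the loss of hydroxy or the presence of acetamido, a question that an amine, a methoxy group or a carboxylic acid at the same place would help to separate. For the compounds shown here, with only one concentration behind these numbers, it also remains open whether compound 4 would inhibit growth at a higher concentration.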